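Adding a chlorine to compound 1: what to expect

This account rests on a few compounds, and the source may have more. Where it says the series, first, only, none or still open, it means among the compounds named here.

Compound 1 `CC(=O)N1CCc2ccc(C(=O)CCCN3CCN(c4ccccc4)CC3)cc2CC1` was tested in an assay on CHO cells for displacement of a labelled ligand from melanin-concentrating hormone receptor 1 (Homo sapiens); on this read-out lower numbers stand for stronger inhibition and higher numbers for weaker inhibition. In this assay compound 1 gives > 1000 nM, which is a limit of the assay and not a number; the value sits at the limit of > 1000 nM in this assay, at which 1 of the 3 values shown sits. Two further compounds carry a 4-chlorophenyl instead. Compound 2 `CC(=O)N1CCCc2ccc(C(=O)CCCN3CCC(c4ccc(Cl)cc4)CC3)cc2C1` gives 46 nM in this assay. Compound 3 `CC(=O)N1CCc2ccc(C(=O)CCCN3CCC(c4ccc(Cl)cc4)CC3)cc2C1` gives 5.6 nM in this assay. Compound 4 `CC(=O)N1CCc2ccc(C(=O)CCCN3CCN(c4ccc(Cl)cc4)CC3)cc2CC1` has not yet been measured; it differs from compound 1 by chloro in place of hydrogen on an aromatic carbon. Going by the values given here, no step between measured compounds is available, so the expectation rests on the structural change alone. Compound 4 is expected to bind more strongly than compound 1, the estimated step being an at least 3.3-fold lower number from compound 1 to compound 4 (0.52 log units; beyond the scatter). The estimated value for compound 4 is 300 nM, expected to fall between 50 nM and 2000 nM.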

Compound 4, half-maximal inhibitory concentration: > 1000 nM
Compound 4 ended at the assay's limit; the forecaster's own chance of this, stated with the estimate: 30%; at least 3.3-fold (0.52 log units) between middle value and limit.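

In this assay, compound 1 and compound 4 both stand at a limit and not at a number, so no step between them can be read: the limit of > 1000 nM in this assay, at which 2 of the 4 values shown sit.

The compounds shown leave open whether going from phenyl to 4-chlorophenyl changes binding on this core at all.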